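The source may hold more compounds than are shown below. What is called first, only, known or untested is meant among the compounds shown, and "the series" means these compounds.

In a functional assay on MCF7 cells (Homo sapiens) for antiproliferative activity, read by sulforhodamine B assay, with a stated time of 48 h (a higher number here means a weaker inhibitor, a lower number a stronger inhibitor), compound 1 `CCCN1CCN(c2ccc(S(=O)(=O)Oc3c(Cl)cc(Cl)cc3Cl)cc2)C1=O` reads > 100000 nM, which is a limit of the assay and not a number. Among the measured compounds shown here, compound 2 `CCCN1CCN(c2ccc(S(=O)(=O)Oc3cccc([N+](=O)[O-])c3)cc2)C1=O` gives 19000 nM, the only actual number so far. The substituent on the sulfonate oxygen separates these two compounds, with 3-nitrophenyl in place of 2,4,6-trichlorophenyl giving an at least 5.2-fold lower number from compound 1 to compound 2 (0.72 log units; beyond the scatter). Compound 3 `CCCN1CCN(c2ccc(S(=O)(=O)Oc3ccc(F)cc3)cc2)C1=O` changes that same place again, with 4-fluorophenyl in place of 3-nitrophenyl on an oxygen. For the measured compounds named here, the step of an at least 5.2-fold lower number from compound 1 to compound 2 (0.72 log units; beyond the scatter) is the only measured evidence that bears on this change. It shows that this substituent can shift the number in this assay, but it starts from a limit and does not involve 4-fluorophenyl, so it gives no direction here. No step beyond the scatter is therefore expected, though with wide uncertainty. The estimate means an expected 1.3-fold higher number from compound 2 to compound 3 (0.12 log units; within the scatter). Compound 3 is expected at 25000 nM, with an estimated range from 7000 nM to 90000 nM.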

Compound 3, half-maximal inhibitory concentration: 33000 nM
Compound 3: the middle estimate sits 1.3-fold (0.12 log units) below what was measured, within the range that was stated.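

In this assay, 4-fluorophenyl in place of 3-nitrophenyl on the sulfonate oxygen gives a 1.7-fold higher number from compound 2 to compound 3 (0.24 log units; within the scatter), so the two groups are not told apart here, although they differ in their heavy atoms and hydrogen-bond acceptors. The other step at this position, an at least 3.0-fold lower number from compound 1 to compound 3 (0.48 log units; beyond the scatter), shows that the gap from 2,4,6-trichlorophenyl does not depend on the nitro group, since it also appears with 4-fluorophenyl. Compound 1 stands at a limit of the assay and not a number, so the true size of both steps from it stays unknown: the limit of > 100000 nM in this assay, at which 1 of the 3 values shown sits.

Going by these compounds, it remains open whether an unsubstituted phenyl, or a phenyl ring carrying an amine or a carboxylic acid, would read differently from these two groups. Also open, on these data alone, is whether a longer chain in place of the propyl chain on the shared core would move the number.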